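From fluoro to nitro on compound 3

This account rests on a few compounds, and the source may have more. Where it says the series, first, only, none or still open, it means among the compounds named here.

Values in an ADME assay on Vero cells (Chlorocebus sabaeus) for cytotoxicity, read by resazurin assay, with a stated time of 72 h (a higher number here means a weaker inhibitor, a lower number a stronger inhibitor), so far
compound 1 `O=C(CCN1CCN(c2ccc([N+](=O)[O-])cc2)CC1)c1ccc(Br)cc1` gives 79800 nM
compound 2 `O=C(CCN1CCN(c2ccc([N+](=O)[O-])cc2)CC1)c1ccc(F)c(Br)c1` gives 256000 nM
compound 3 `O=C(CCN1CCN(c2ccc(F)cc2)CC1)c1ccc(F)c(F)c1` gives 385000 nM

The numbers of compound 3 and compound 2 lie within the usual scatter of each other, and both stand clearly above that of compound 1. Compound 4 `O=C(CCN1CCN(c2ccc([N+](=O)[O-])cc2)CC1)c1ccc(F)c(F)c1` differs from compound 3 in one place: nitro in place of fluoro on an aromatic carbon, which reads 4-fluorophenyl to 4-nitrophenyl. For the measured compounds named here, no measured step makes this exchange directly. Going by the values given here, the only single-place step, a 3.2-fold higher number from compound 1 to compound 2 (0.51 log units; beyond the scatter), is a modest one, and it concerns the group on the carbonyl carbon rather than this position. The closest guide is compound 2, which carries the 4-nitrophenyl and gives 256000 nM in this assay. Only a small move toward a lower number is therefore expected, possibly none beyond the scatter. The expected change is a 1.8-fold lower number from compound 3 to compound 4 (0.26 log units; within the scatter) overall. For compound 4 the estimated value is 210000 nM, with 90000 nM to 450000 nM as the expected range.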

Compound 4, half-maximal inhibitory concentration: 122000 nM
For compound 4 the middle estimate is 1.7-fold (0.24 log units) above the measured one; measured number inside the range.
By their numbers in this assay, from the lowest: compounds 1 and 4 (each within the scatter of the next); then compounds 2 and 3 (each within the scatter of the next).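

In this assay the exchange of fluoro for nitro at this position is now measured directly and gives a 3.2-fold lower number from compound 3 to compound 4 (0.50 log units; beyond the scatter) with the 3,4-difluorophenyl on the carbonyl carbon held fixed. With the 4-nitrophenyl held fixed instead, the group on the carbonyl carbon gains two further comparisons, a 2.1-fold lower number from compound 2 to compound 4 (0.32 log units; beyond the scatter) and a 1.5-fold higher number from compound 1 to compound 4 (0.18 log units; within the scatter), so fluoro in place of bromo moves the number beyond the scatter, whereas 3,4-difluorophenyl and 4-bromophenyl are not told apart. No measurement at hand gives a reason for either shift.

The compounds shown leave open whether the step from fluoro to nitro holds with other groups on the carbonyl carbon. They also leave open how this assay would read an amine or a carboxylic acid at that aromatic carbon.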